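Swapping a uracil for a bromopurine on the seven-membered ring

The compounds below may be only part of what the source reports. "The series", "measured", "known", "first", "only" and "open" are said of these compounds alone.

Compound 1 `O=c1cc[nH]c(=O)n1C1CN(S(=O)(=O)c2ccccc2[N+](=O)[O-])c2ccccc2CO1` is the weakest inhibitor in this set: in a functional assay on MCF7 cells (Homo sapiens) for cytotoxicity, read by sulforhodamine B assay, with a stated time of 3 days (a higher number here means a weaker inhibitor, a lower number a stronger inhibitor), compound 1 gives 50900 nM, the highest of the three numbers measured. Compound 2 `O=[N+]([O-])c1ccc(S(=O)(=O)N2C[C@H](n3cnc4c(Cl)nc(Cl)nc43)OCc3ccccc32)cc1` gives 190 nM and compound 3 `O=[N+]([O-])c1ccc(S(=O)(=O)N2C[C@@H](n3cnc4c(Cl)nc(Cl)nc43)OCc3ccccc32)cc1` gives 100 nM. Among the compounds with values here, those two are mirror-image arrangements at one saturated ring carbon, and the step of a 1.9-fold lower number from compound 2 to compound 3 (0.28 log units; within the scatter) is the only measured step here; it rests on the fact that compounds 2 and 3 differ only in the configuration as drawn and tells nothing about exchanging one attached group for another.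

Compound 4 `O=[N+]([O-])c1ccccc1S(=O)(=O)N1CC(n2cnc3c(Br)ncnc32)OCc2ccccc21` differs from compound 1 by a group of 10 heavy atoms (5 carbon, 4 nitrogen, 1 bromine; one five-membered aromatic ring with 2 hetero atoms, one six-membered aromatic ring with 2 hetero atoms) in place of a group of 8 heavy atoms (4 carbon, 2 nitrogen, 2 oxygen; one six-membered aromatic ring with 2 hetero atoms), on a saturated ring carbon. Within the data shown here, no measured pair isolates this exchange. Compounds 2 and 3 carry a related dichlorinated two-ring group on the same carbon, and their numbers are far lower than that of compound 1, but they also differ from compound 1 elsewhere, so they give only a hint rather than a direct step.

Taking that hint, compound 4 is expected to give a much lower number, a step of an 85-fold lower number from compound 1 to compound 4 (1.93 log units; beyond the scatter). The estimate for compound 4 is 600 nM, within a range from 100 nM to 4000 nM; the range is wide, the exchange itself having no direct test.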

Compound 4, half-maximal inhibitory concentration: 3620 nM
Compound 4: middle estimate off by 6.0-fold (0.78 log units), on the low side, within the range that was stated.
By their numbers in this assay, from the lowest: compounds 3 and 2 (each within the scatter of the next); then compound 4; then compound 1.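

In this assay, putting the two-ring group that carries bromine in place of the single-ring group, on the saturated ring carbon next to the ring oxygen, gives a 14-fold lower number from compound 1 to compound 4 (1.15 log units; beyond the scatter). Within the data shown here, this is the first measured step in which the group on this carbon is exchanged while the rest of the molecule stays the same, so it shows that the choice of group at this position can by itself move the number beyond the usual scatter, whereas the earlier step between mirror-image arrangements changed only the configuration as drawn. Among these compounds, nothing measured here explains why this exchange lowers the number, and the single step does not separate the contribution of the second ring from that of the bromine.

As far as these compounds go, it remains open whether the lower number would persist if an amine or a methoxy group stood in place of the bromine, or if the two-ring group carried no such substituent at all. From the compounds shown here alone, compounds 1 and 4 are also drawn without a set configuration at this carbon, so how the two separate arrangements of compound 4 would compare is unknown.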